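Compound 4: 2-chloropyridin-4-yl replaces 2-chlorophenyl

The compounds below may be only part of what the source reports. "The series", "measured", "known", "first", "only" and "open" are said of these compounds alone.

Three compounds have been measured in a functional assay on HepG2 cells (Homo sapiens) for cytotoxicity, read by MTT assay, with a stated time of 48 h; a higher number here means a weaker inhibitor, a lower number a stronger inhibitor:

compound 1 `Cc1ncc([N+](=O)[O-])n1CCSc1nnc(-c2ccccc2N)o1` gives 4500 nM
compound 2 `Cc1ncc([N+](=O)[O-])n1CCSc1nnc(-c2ccccc2[N+](=O)[O-])o1` gives 700 nM
compound 3 `Cc1ncc([N+](=O)[O-])n1CCSc1nnc(-c2ccccc2Cl)o1` gives 15600 nM

Compound 3 has the highest number of the three, so it is the weakest inhibitor in this assay. Its nearest neighbour is compound 1: a 3.5-fold higher number from compound 1 to compound 3 (0.54 log units; beyond the scatter). Its furthest is compound 2: a 22-fold higher number from compound 2 to compound 3 (1.35 log units; beyond the scatter).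

Compound 4 `Cc1ncc([N+](=O)[O-])n1CCSc1nnc(-c2ccnc(Cl)c2)o1` is not yet measured. It differs from compound 3 in one place: 2-chloropyridin-4-yl in place of 2-chlorophenyl on an aromatic carbon. The group that leaves and the group that enters carry the same chloro, so the change is the ring nitrogen that enters.

Within the data shown here, none of the measured steps bears directly on this change. The three measured steps all swap the group on the six-membered ring of carbon only (amino, nitro, chloro) and leave that ring itself untouched: a 6.4-fold lower number from compound 1 to compound 2 (0.81 log units; beyond the scatter), a 3.5-fold higher number from compound 1 to compound 3 (0.54 log units; beyond the scatter), a 22-fold higher number from compound 2 to compound 3 (1.35 log units; beyond the scatter). They show that changes on this part of the molecule can move the number beyond the scatter, but give no direction for a ring nitrogen.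

Among the measured compounds shown here, with no guiding step, the number for compound 4 is expected to stay close to that of compound 3, a 1.0-fold lower number from compound 3 to compound 4 (0.02 log units; within the scatter), with a wide range in either direction. Compound 4 is estimated at 15000 nM, between 4000 nM and 50000 nM.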

Compound 4, half-maximal inhibitory concentration: 11600 nM
Estimate against measurement, compound 4: 1.3-fold (0.11 log units) above; the range from low to high includes it.
By their numbers in this assay, from the lowest: compound 2; then compound 1; then compounds 4 and 3 (each within the scatter of the next).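

In this assay, the ring nitrogen that enters with 2-chloropyridin-4-yl gives a 1.3-fold lower number from compound 3 to compound 4 (0.13 log units; within the scatter), so unlike the earlier swaps of the group on the ring, this change to the ring itself gives no shift that can be told apart from repeat-measurement scatter, even though it adds a hydrogen-bond acceptor. Against the 2-aminophenyl compound, the new ring gives a 2.6-fold higher number from compound 1 to compound 4 (0.41 log units; beyond the scatter), so a difference beyond the scatter remains between these two compounds. No supporting data are available to explain why the ring nitrogen leaves the number so little changed.

The compounds shown pair the ring nitrogen with chloro only, so it remains open whether it would also leave the number in place alongside the nitro group of compound 2 or the amino group of compound 1. Also open, on these data alone, is what a ring nitrogen elsewhere in this ring would do, or what a methoxy group or a carboxylic acid would do in place of the chloro on the pyridine ring.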